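The source may hold more compounds than are shown below. What is called first, only, known or untested is meant among the compounds shown, and "the series" means these compounds.

Three compounds have been measured in a functional assay on HepG2 cells (Homo sapiens) for inhibition, read by MTT assay, with a stated time of 48 h; a lower number here means a stronger inhibitor, a higher number a weaker inhibitor:

compound 1, `CCOC(=O)C1=C(NN=C(C#N)C#N)Nc2[nH]nc(C)c2C1c1ccc(N(C)C)cc1`, gives 13700 nM
compound 2, `CCOC(=O)C1=C(N/N=C(/Cl)c2ccc([N+](=O)[O-])cc2)Nc2[nH]nc(C)c2C1c1ccc(N(C)C)cc1`, gives 55500 nM
compound 3, `CCOC(=O)C1=C(N/C=N/c2ccc([N+](=O)[O-])cc2)Nc2[nH]nc(C)c2C1c1ccc(N(C)C)cc1`, gives 50900 nM

Compound 2 gives the highest of the three numbers, although compound 3 sits within the scatter of it, so those two are not told apart. Compound 1 stands clearly apart from both: a 4.1-fold higher number from compound 1 to compound 2 (0.61 log units; beyond the scatter) and a 3.7-fold higher number from compound 1 to compound 3 (0.57 log units; beyond the scatter), each modest but beyond the scatter.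

Compound 4, `CCOC(=O)C1=C(N/N=C(/C(C)=O)C(=O)OCC)Nc2[nH]nc(C)c2C1c1ccc(N(C)C)cc1`, has not yet been measured. It differs from compound 2 in one place: a group of 10 heavy atoms (6 carbon, 1 nitrogen, 3 oxygen; no ring) in place of a group of 12 heavy atoms (7 carbon, 2 nitrogen, 2 oxygen, 1 chlorine; one six-membered aromatic ring of carbon only), on an amine nitrogen. The group that enters carries no ring, which it shares with the group in compound 1 and not with the groups in compound 2 and compound 3. Among the measured compounds shown here, the measured step that bears most on this change is the one from compound 1 to compound 2, read backwards: because a 4.1-fold higher number from compound 1 to compound 2 (0.61 log units; beyond the scatter) went from a ring-free group to a ring-bearing one, the return to a ring-free group in compound 4 is expected to lower the number. The group in compound 4 is not the group of compound 1, so only part of that distance is expected to be recovered, giving an expected step of a 2.2-fold lower number from compound 2 to compound 4 (0.35 log units; beyond the scatter). The estimate for compound 4 is 25000 nM, with a range from 8000 nM to 70000 nM.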

Compound 4, half-maximal inhibitory concentration: > 100000 nM
Compound 4: a limit, no number (the forecaster's own chance of this, stated with the estimate: 5%); middle value at least 4.0-fold (0.60 log units) away from the limit.
By their numbers in this assay, from the lowest: compound 1; then compounds 3 and 2 (each within the scatter of the next). At a limit, above all of these: compound 4.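

In this assay, compound 4 gives a limit of the assay and not a number: the limit of > 100000 nM in this assay, at which 1 of the 4 values shown sits. On this amine nitrogen, a group with no ring does not by itself go with a lower number: compound 1 fits that idea, but compound 4 goes against it, and the two ring-free groups are clearly separated (an at least 7.2-fold higher number from compound 1 to compound 4 (0.86 log units; beyond the scatter)). The steps from the two ring-bearing groups (an at least 1.8-fold higher number from compound 2 to compound 4 (0.25 log units; that floor lies within the scatter)) and (an at least 1.9-fold higher number from compound 3 to compound 4 (0.29 log units; that floor lies within the scatter)) have floors within the scatter, so the limit alone does not set compound 4 apart from those two compounds, and what counts at this position is the particular group rather than the presence or absence of a ring.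

The exact size of all three steps stays unknown, and nothing shown tells which part of the group in compound 4 separates it from the group in compound 1. Also open, as far as these compounds go, is where a group such as a carboxylic acid, an amine or a longer alkyl chain on this nitrogen would fall in this assay, with the rest of the core kept the same.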